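The source may hold more compounds than are shown below. What is called first, only, known or untested is meant among the compounds shown, and "the series" means these compounds.

Measured so far:
- compound 1 `Cc1ccc(-n2nc(-c3ccc4ccccc4c3)nc2N2C(=O)COC23C=CC(=O)C=C3)cc1` gives 110 nM
- compound 2 `O=C1C=CC2(C=C1)OCC(=O)N2c1nc(-c2ccc3ccccc3c2)nn1-c1ccc2ccccc2c1` gives 250 nM

In a functional assay on A549 cells (Homo sapiens) for antiproliferative activity, with a stated time of 5 days (on this read-out lower numbers stand for stronger inhibition and higher numbers for weaker inhibition), compound 2 stands at 250 nM, the higher of the two numbers. The next candidate is compound 3 `O=C1C=CC2(C=C1)OCC(=O)N2c1nc(-c2ccc3ccccc3c2)nn1-c1ccc(C(F)(F)F)cc1`, with 4-(trifluoromethyl)phenyl in place of naphthalen-2-yl on an aromatic nitrogen.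

Among the measured compounds shown here, one measured step bears on this change, at the same nitrogen: a 2.3-fold higher number from compound 1 to compound 2 (0.36 log units; beyond the scatter). It is modest but beyond the scatter, and it runs from 4-methylphenyl to naphthalen-2-yl. For the measured compounds named here, the entering group, like the 4-methylphenyl of compound 1 , has one six-membered aromatic ring of carbon only, but no measured compound carries trifluoromethyl. A modest fall in this assay is therefore expected, roughly reversing that step, and it may not clear the scatter. The expected change is a 1.8-fold lower number from compound 2 to compound 3 (0.25 log units; within the scatter). For compound 3 the estimated value is 140 nM, within a range of 60 nM to 320 nM.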

Compound 3, half-maximal inhibitory concentration: 460 nM
Beside the measured number, compound 3's estimate is 3.3-fold (0.52 log units) below it, and the stated range ends below it.
By their numbers in this assay, from the lowest: compound 1; then compounds 2 and 3 (each within the scatter of the next).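

In this assay, exchanging naphthalen-2-yl for 4-(trifluoromethyl)phenyl on the aromatic nitrogen gives a 1.8-fold higher number from compound 2 to compound 3 (0.26 log units; within the scatter), so among these compounds the loss of one six-membered aromatic ring does not by itself return the number to that of compound 1. The two groups with a single such ring are instead separated clearly, with trifluoromethyl in place of methyl giving a 4.2-fold higher number from compound 1 to compound 3 (0.62 log units; beyond the scatter), so at this position the group on the phenyl ring counts for more here than the number of aromatic rings. No measurement is available that explains this difference.

As far as these compounds go, whether methyl is specifically favoured remains open, since unsubstituted phenyl, 4-methoxyphenyl or 4-aminophenyl on this nitrogen would test that. From the compounds shown here alone, all three compounds also keep naphthalen-2-yl on the ring carbon, so it is unknown whether the trend holds with another group there.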